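A few compounds are considered here, and "the series" means these few. Any claim that something is new, unique, unknown or untested is made for them only; others in the source may bear on it.

Measured compounds and their values in a functional assay on BXPC-3 cells (Homo sapiens) for inhibition, read by MTT assay, with a stated time of 72 h; a higher number here means a weaker inhibitor of growth, a lower number a stronger inhibitor of growth:
Compound 1, `O=S(=O)(NCCNCc1cccc2ccccc12)c1cc(C(F)(F)F)cc(C(F)(F)F)c1`, gives 23000 nM.
Compound 2, `CC(C)(C)c1ccc(CNCCCNS(=O)(=O)c2cc(C(F)(F)F)cc(C(F)(F)F)c2)cc1`, gives 1400 nM.
Compound 3, `O=S(=O)(NCCNCc1ccc(-c2ccccc2)cc1)c1cc(C(F)(F)F)cc(C(F)(F)F)c1`, gives 1600 nM.

Among these three numbers compound 2 has the lowest. Compound 3 sits within the usual scatter of it, so the two cannot be told apart on these numbers alone. Compound 1 lies well beyond the scatter, with a much higher number than compound 2, which marks it as the weaker growth inhibitor of the three.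

The compound not yet measured is compound 4, `O=S(=O)(NCCCNCc1ccc(Cl)c(C(F)(F)F)c1)c1cc(C(F)(F)F)cc(C(F)(F)F)c1`. It differs from compound 2 in one place: 4-chloro-3-(trifluoromethyl)phenyl in place of 4-(tert-butyl)phenyl on a saturated chain carbon bound to an amine nitrogen. Both groups are a single six-membered aromatic ring of carbon only, with no hydrogen-bond donors or acceptors and no net charge, attached at the same position on the chain. Among the measured compounds shown here, no step between two measured compounds bears on this kind of exchange, so nothing here shows how swapping one such ring for the other moves the readout.

In this assay compound 4 is expected to give a step of a 1.1-fold higher number from compound 2 to compound 4 (0.03 log units; within the scatter), that is, no change beyond the scatter in either direction. In this assay compound 4 is estimated at 1500 nM, with a range from 500 nM to 5000 nM.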

Compound 4, concentration for 50% growth inhibition: 7800 nM
Compound 4: middle estimate off by 5.2-fold (0.72 log units), on the low side; the whole stated range lies below it.
By their numbers in this assay, from the lowest: compounds 2 and 3 (each within the scatter of the next); then compound 4; then compound 1.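

In this assay, the exchange on a saturated chain carbon bound to an amine nitrogen gives a 5.6-fold higher number from compound 2 to compound 4 (0.75 log units; beyond the scatter), a step beyond the scatter, so the readout at this position depends on which aromatic group is attached. The step appears even though the counted features stay the same: 4-(tert-butyl)phenyl and 4-chloro-3-(trifluoromethyl)phenyl are each one six-membered aromatic ring of carbon only, with no hydrogen-bond donors or acceptors and no net charge, and they differ little in heavy-atom count. Nothing measured here explains why the replacement weakens growth inhibition.

Because chlorine and trifluoromethyl enter together along with the loss of tert-butyl, the compounds shown cannot say whether one of the two new groups accounts for the step, which a ring carrying only chlorine or only trifluoromethyl could help separate. They also leave open how this position would respond to a ring bearing a carboxylic acid or an amine, and whether the same exchange would give a similar step on a different chain, since compound 1 and compound 3 each differ from compound 2 in more than one place.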